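The source may report more compounds than this note shows. Statements on the series, on what has been measured and on what is new or still open speak of the compounds shown alone.

This account follows a small set of compounds that share one core and differ at a single position. Compound 1 `CC(CSC(CCc1ccccc1[N+](=O)[O-])c1cccc(OCc2ccc3ccc(Cl)cc3n2)c1)C(=O)O`, compound 2 `O=C(O)CCSC(CCc1ccccc1-c1nc[nH]n1)c1cccc(OCc2ccc3ccc(Cl)cc3n2)c1` and compound 3 `CCC(CSC(CCc1ccccc1C(=O)O)c1cccc(OCc2ccc3ccc(Cl)cc3n2)c1)C(=O)O` have each been run in an in vivo ADME assay on the whole organism (plasma) for pharmacokinetics, with Rattus norvegicus as the target, at a dose of 5 mg/kg by the intravenous route; on this read-out higher numbers stand for fast clearance and lower numbers for slow clearance. Compound 1 gives 12 mL/min/kg, compound 2 gives 64 mL/min/kg, and compound 3 gives 8.8 mL/min/kg. Compound 3 thus holds the lowest of the three numbers, with compound 1 lying within the scatter of it and compound 2 lying well beyond it. Compound 4 `CCC(CSC(CCc1ccccc1-c1nnnn1C)c1cccc(OCc2ccc3ccc(Cl)cc3n2)c1)C(=O)O` differs from compound 3 in one place: 1-methyl-1H-tetrazol-5-yl in place of carboxy on an aromatic carbon, ortho to a large group. The value of compound 2 in this assay suggests that the swap pulls the number upward, so the step is expected to be a rise of a 3.4-fold higher number from compound 3 to compound 4 (0.53 log units; beyond the scatter) beyond the scatter. Compound 4 is therefore estimated at 30 mL/min/kg, within a range of 12 mL/min/kg to 70 mL/min/kg.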

Compound 4, clearance: 18 mL/min/kg
Beside the measured number, compound 4's estimate is 1.7-fold (0.22 log units) above it; the range from low to high includes it.
By their numbers in this assay, from the lowest: compounds 3, 1 and 4 (each within the scatter of the next, the first and the last beyond it); then compound 2.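

Among these compounds, with this assay, the exchange of carboxy for 1-methyl-1H-tetrazol-5-yl on an aromatic carbon gives a 2.0-fold higher number from compound 3 to compound 4 (0.31 log units; beyond the scatter) as the first step read at this position, since no earlier pair differed in one place. The step is modest but beyond the scatter, so this position does register the change. Nothing measured here bears on why the number moves.

As far as these compounds go, whether an unmethylated tetrazole or a primary amide in the same place would give a similar number stays open. So does whether the step would carry over to a shorter acid chain elsewhere on the shared core.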